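This account rests on a few compounds, and the source may have more. Where it says the series, first, only, none or still open, it means among the compounds named here.

Two compounds of this series carry a measurement. Compound 1 `CC1=C(/C=C/C(=O)/C=C/c2ccc(F)cc2)C(C)(C)CCC1` gives 55800 nM in a functional assay on Hep cells (Homo sapiens) for cytotoxicity, read by sulforhodamine B assay, with a stated time of 48 h; a higher number here means a weaker inhibitor, a lower number a stronger inhibitor; compound 2 `COc1ccccc1/C=C/C(=O)/C=C/C1=C(C)CCCC1(C)C` gives 38900 nM in this assay, the lower of the two numbers, although the gap to compound 1 lies within the scatter. Compound 3 `CC1=C(/C=C/C(=O)/C=C/c2ccccc2C)C(C)(C)CCC1` is not yet measured; it differs from compound 2 by methyl in place of methoxy on an aromatic carbon. Within the data shown here, no measured pair shows the effect of this change, so no step beyond the scatter is expected in either direction. For compound 3 the expected value is 40000 nM, with a range of 15000 nM to 100000 nM. The expected step of a 1.0-fold higher number from compound 2 to compound 3 (0.01 log units; within the scatter) is thus small.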

Compound 3, half-maximal inhibitory concentration: 41000 nM
Beside the measured number, compound 3's estimate is 1.0-fold (0.01 log units) below it; measured number inside the range.
By their numbers in this assay, from the lowest: compounds 2, 3 and 1 (each within the scatter of the next).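

With this assay as the read-out, this aromatic carbon, ortho to a large group, now has its first measured pair: methyl in place of methoxy gives a 1.1-fold higher number from compound 2 to compound 3 (0.02 log units; within the scatter) and so shows no step beyond the scatter. 2-Methylphenyl in place of 4-fluorophenyl gives a 1.4-fold lower number from compound 1 to compound 3 (0.13 log units; within the scatter) and likewise stays within the scatter. Nothing available accounts for these results. From the compounds shown here alone, whether an amine or a carboxylic acid at this position would give a step beyond the scatter remains open. The same question stands for a longer chain there.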